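Tetrazolylmethyl in place of the cyclic sulfonamide on the core

A few compounds are considered here, and "the series" means these few. Any claim that something is new, unique, unknown or untested is made for them only; others in the source may bear on it.

Compound 1 `CC(C)C(c1ccc(-c2ccc3cccc(F)c3c2)[nH]c1=O)N1CCCCS1(=O)=O` is the anchor of this set. In an ADME assay on microsomes from liver (Homo sapiens) for metabolic stability (a higher number here means that the compound lasts longer, a lower number that the compound disappears faster), compound 1 gives 0.373 h, the lowest of the two numbers recorded; its nearest neighbour is compound 2 `CC(C)C(c1nnc[nH]1)c1ccc(-c2ccc3cccc(F)c3c2)[nH]c1=O`, which gives 0.905 h. Compound 3 `CC(C)C(c1ncc[nH]1)c1ccc(-c2ccc3cccc(F)c3c2)[nH]c1=O` reports only a limit of the assay, < 0.0667 h, and not a number (the limit of < 0.0667 h in this assay, at which 1 of the 3 values shown sits). The measured steps run in opposite directions: a 2.4-fold higher number from compound 1 to compound 2 (0.38 log units; beyond the scatter), while an at least 5.5-fold lower number from compound 1 to compound 3 (0.74 log units; beyond the scatter) and an at least 13-fold lower number from compound 2 to compound 3 (1.13 log units; beyond the scatter).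

The step to compound 4 `CC(C)C(Cc1nnn[nH]1)c1ccc(-c2ccc3cccc(F)c3c2)[nH]c1=O` alters the same position: a group of 6 heavy atoms (2 carbon, 4 nitrogen; one five-membered aromatic ring with 4 hetero atoms) in place of a group of 8 heavy atoms (4 carbon, 1 nitrogen, 2 oxygen, 1 sulfur; one six-membered non-aromatic ring with 2 hetero atoms), on a saturated chain carbon bound to an aromatic carbon and a saturated chain carbon. Both recorded steps at this position bear on it, one modest and upward, one at least modest and downward, so either direction is open; a five-membered aromatic ring with many hetero atoms, as in compound 2, is the closer precedent, and the expectation leans modestly upward. The expected step is a 1.6-fold higher number from compound 1 to compound 4 (0.21 log units; within the scatter). Compound 4 is estimated at 0.6 h, within a range of 0.2 h to 1.8 h.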

Compound 4, half-life: > 3 h
Compound 4 gave a limit, no number; the forecaster's own chance of this, stated with the estimate: 8%; middle value at least 5.0-fold (0.69 log units) away from the limit.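

Compound 4 reports > 3 h in this assay, a limit and not a number. The (1H-tetrazol-5-yl)methyl group on this saturated chain carbon gives an at least 8.0-fold higher number from compound 1 to compound 4 (0.90 log units; beyond the scatter), an at least 3.3-fold higher number from compound 2 to compound 4 (0.52 log units; beyond the scatter) and an at least 44-fold higher number from compound 3 to compound 4 (1.65 log units; beyond the scatter), so compound 4 holds the highest reading of the four compounds shown. The earlier compounds shown here placed the ring changes on either side of compound 1, whereas this result shows that compound 2 did not mark the ceiling at this position.

Compound 4 differs from compound 2 in both the ring and the methyl link, and the compounds shown do not separate these two changes; 1H-tetrazol-5-yl set directly on the chain carbon, or 4H-1,2,4-triazol-3-yl carried on a methyl link, would do so. On these data alone, whether a carboxylic acid on the same methyl link would hold the reading also stays open.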